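Trifluoromethyl in Place of Methoxy: Compound 3 to Compound 4

The compounds below may be only part of what the source reports. "The series", "measured", "known", "first", "only" and "open" are said of these compounds alone.

Of the compounds shown here, three built on one shared core have been measured in a functional assay on HL-60 cells (Homo sapiens) for cytotoxicity, read by luminescence and CellTiter-Glo, with a stated time of 3 days; a higher number here means a weaker inhibitor, a lower number a stronger inhibitor. Compound 1 `O=C(Nc1cc(C(F)(F)F)cc(C(F)(F)F)c1)c1cc(Br)c(-c2ccccc2)cc1O` gives 430 nM, and compound 2 `O=C(Nc1ccc(Cl)c(Cl)c1)c1cc(F)ccc1O` gives 660 nM; these two values lie within the usual scatter of each other, so neither can be called the stronger. Compound 3 `COc1ccc(O)c(C(=O)Nc2ccc(C#N)cc2)c1` returns no number at all but only a limit, > 10000 nM. Among the measured compounds shown here, this is the limit described by the limit of > 10000 nM in this assay, at which 1 of the 3 values shown sits, and compound 3 is the one compound of the three that sits at it.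

Compound 4 `N#Cc1ccc(NC(=O)c2cc(C(F)(F)F)ccc2O)cc1` has not yet been measured. It differs from compound 3 in one place: trifluoromethyl in place of methoxy on an aromatic carbon. For the measured compounds named here, no two of the measured compounds differ from one another in a single place, so no measured step shows what this particular change does, and the size of any step starting from compound 3 cannot be fixed from its side, as only a limit is known for it.

Compound 4 is nevertheless expected to give a number rather than a limit, estimated at 3000 nM with a range from 800 nM to 12000 nM. The step from compound 3 to compound 4 that this estimate means, an at least 3.3-fold lower number from compound 3 to compound 4 (0.52 log units; beyond the scatter), is expected to be a gain beyond the scatter.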

Compound 4, half-maximal inhibitory concentration: 3120 nM
For compound 4 the middle estimate is 1.0-fold (0.02 log units) below the measured one; measured number inside the range.
By their numbers in this assay, from the lowest: compounds 1 and 2 (each within the scatter of the next); then compound 4. At a limit, above all of these: compound 3.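

In this assay, trifluoromethyl in place of methoxy on this aromatic carbon, para to a hydroxy group and meta to a large group, gives an at least 3.2-fold lower number from compound 3 to compound 4 (0.50 log units; beyond the scatter), the only step among the compounds shown that isolates a change in a single place. Among the compounds shown here, with the rest of the structure unchanged, the group on this one carbon is enough to separate a compound that stays at a limit from one that gives a number, which the earlier compounds could not show. The true size of the step remains unknown because compound 3 stands at a limit, not at a number: the limit of > 10000 nM in this assay, at which 1 of the 4 values shown sits.

What the compounds shown leave open is how another group on this same carbon, such as an amine, a carboxylic acid or a longer chain, would compare with methoxy and trifluoromethyl. From the compounds shown here alone, it is also open whether the same exchange would give a step of similar size in a compound with a group other than nitrile on the far ring of the shared core.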